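Chloro in place of fluoro: compound 3 in the series

This account rests on a few compounds, and the source may have more. Where it says the series, first, only, none or still open, it means among the compounds named here.

Measured so far:
compound 1 `O=C(/C=C/c1ccccc1[N+](=O)[O-])NS(=O)(=O)c1ccccc1`: 6 ug/mL
compound 2 `O=C(/C=C/c1ccccc1[N+](=O)[O-])NS(=O)(=O)c1ccc(F)cc1`: 6 ug/mL

Both compounds share one core and were run in a functional assay on B16-F10 cells (Mus musculus) for antiproliferative activity, read by ELISA and MTT assay, with a stated time of 48 h; on this read-out lower numbers stand for stronger inhibition and higher numbers for weaker inhibition. Within the data shown here, compound 1 gives 6 ug/mL and compound 2 gives 6 ug/mL, so the single measured step, no change at the digits printed from compound 1 to compound 2 (within the scatter), shows no change beyond the scatter. Among the measured compounds shown here, compound 2 thus stands level with compound 1, its only neighbour on the numbers available.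

Compound 3 `O=C(/C=C/c1ccccc1[N+](=O)[O-])NS(=O)(=O)c1ccc(Cl)cc1` is the next member, not yet measured. Its difference from compound 2 is chloro in place of fluoro on an aromatic carbon. For the measured compounds named here, only the step from compound 1 to compound 2 bears on this change, and it was flat, so the data give no direction for a halogen-to-halogen exchange at the same place. Going by the values given here, the expectation is therefore a step of no change at the digits printed from compound 2 to compound 3 (within the scatter) from compound 2 to compound 3, that is, none beyond the scatter, with the range widened because the chloro analogue itself has no precedent here. Compound 3 is accordingly estimated at 6 ug/mL in this assay, expected between 3 ug/mL and 12 ug/mL.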

Compound 3, half-maximal inhibitory concentration: 6.6 ug/mL
The estimate for compound 3 lay 1.1-fold (0.04 log units) below the measured number; the measured number falls inside the stated range.
By their numbers in this assay, from the lowest: compounds 1, 2 and 3 (each within the scatter of the next).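

In this assay the change from 4-fluorophenyl to 4-chlorophenyl gives a 1.1-fold higher number from compound 2 to compound 3 (0.04 log units; within the scatter) and so shows that a second halogen at this place reads level with the first. Chloro in place of hydrogen on the same aromatic carbon gives a 1.1-fold higher number from compound 1 to compound 3 (0.04 log units; within the scatter) and adds a second substituent to the flat step already seen with fluoro. Hydrogen, fluoro and chloro, para to a large group, are therefore not separated by this read-out, a statement that holds for compound 1, compound 2 and compound 3 only.

Still open, as far as these compounds go, is whether this flatness extends beyond the halogens at this place, for example to an amine, a methoxy group or a carboxylic acid. The compounds shown also leave open how much the nitro group and the double bond of the shared core contribute, as both stay the same in all three compounds. Nothing at hand accounts for the flat response at this position.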